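The source may hold more compounds than are shown below. What is called first, only, known or untested is meant among the compounds shown, and "the series" means these compounds.

Measured so far:
Compound 1 `COc1cc2oc(-c3ccc(NC(=O)c4ccc(C)cc4)cc3)cc(=O)c2c(OC)c1OC`. In a functional assay on RPMI-8226 cells (Homo sapiens) for inhibition, read by sulforhodamine B assay, tested at 10 uM (a lower number here means less inhibition, a higher number more inhibition at the concentration tested (going by the name of the read-out)), compound 1 gives <= 42.6%, which is a limit of the assay rather than a number.
Compound 2 `COc1cc2oc(-c3cccc(C(=O)Nc4ccc(C)cc4)c3)cc(=O)c2c(OC)c1OC`. Compound 2 gives 82.6%.
Compound 3 `COc1cc2oc(-c3cccc(C(=O)Nc4ccc(Cl)cc4)c3)cc(=O)c2c(OC)c1OC`. Compound 3 gives 82.6%.

Compound 2 stands level with compound 3 at the digits shown, and the one measured step, no change at the digits printed from compound 2 to compound 3 (within the scatter), stays within the scatter of repeated measurements. For the measured compounds named here, the value of compound 1 is a limit, so no step can be drawn from it.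

The compound still to be measured is compound 4 `COc1cc2oc(-c3cccc(C(=O)Nc4ccc(C)cc4)c3)cc(=O)c2c(O)c1OC`, which differs from compound 2 in a single place: hydrogen in place of methyl on an oxygen on an aromatic ring. Going by the values given here, no measured step touches this kind of change; the step from compound 2 to compound 3 concerns a different position and a different pair of groups. Nothing shown therefore points to a shift in either direction, and the expectation rests on compound 2 alone. The step of a number 6.6 percentage points lower from compound 2 to compound 4 (within the scatter) is expected to stay within the scatter. For compound 4 the estimate is 76%, with a range from 50% to 92%.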

Compound 4, a percentage reported as inhibition, at one concentration (the size of the read-out at that concentration, not a potency): 82.6%
Beside the measured number, compound 4's estimate is 6.6 percentage points below it; the range from low to high includes it.
By their numbers in this assay, from the lowest: compounds 2, 3 and 4 (each within the scatter of the next). At a limit, below all of these: compound 1.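

In this assay, going from methoxy to hydroxy gives no change at the digits printed from compound 2 to compound 4 (within the scatter), so at the concentration tested, the methyl on this oxygen can be removed without a visible loss of inhibition. The earlier step changed only methyl to chloro on an aromatic carbon, whereas this one touches the shared core, and it shows that the core accepts this one change. The only limit among the compounds shown belongs to compound 1, and it plays no part in this step: the limit of <= 42.6% in this assay, at which 1 of the 4 values shown sits.

As far as these compounds go, a reading at one concentration gives the size of the inhibition rather than a potency, so any difference between compound 2 and compound 4 at other concentrations remains unknown. From the compounds shown here alone, it also remains open whether an ethyl group or a longer chain on this oxygen, or an amine in place of the hydroxy, would give a similar reading.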